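Phenyl in Place of Furan-2-yl: an Expected Cell Potency

The source may report more compounds than this note shows. Statements on the series, on what has been measured and on what is new or still open speak of the compounds shown alone.

Compound 1 `COc1ccc(S(=O)(=O)N2CCc3cccc(-c4ccco4)c32)cc1` gives the lowest number of the three measured in a functional assay on KB-VIN10 cells (Homo sapiens) for inhibition, with a stated time of 72 h (a lower number here means a stronger inhibitor, a higher number a weaker inhibitor), at 79.2 nM. Compound 2 `COc1ccc(S(=O)(=O)N2CCc3cccc(-c4cccnc4)c32)cc1` gives 84.5 nM in this assay and lies a 1.1-fold higher number from compound 1 to compound 2 (0.03 log units; within the scatter). Compound 3 `COc1ccc(S(=O)(=O)N2CCc3cccc(-c4c(F)c(F)c(F)c(F)c4F)c32)cc1` gives 4630 nM in this assay, far from compound 1. Compound 4 `COc1ccc(S(=O)(=O)N2CCc3cccc(-c4ccccc4)c32)cc1` differs from compound 1 in one place: phenyl in place of furan-2-yl on an aromatic carbon. The step from compound 1 to compound 2 bears most directly on this change, since it also exchanges one aromatic ring for another on the same carbon, and it stayed within the scatter. Compound 3 is less telling, as it carries a pentafluorophenyl rather than a plain phenyl. Compound 4 is therefore expected to give 100 nM, with a range of 40 nM to 300 nM. The expected step is a 1.3-fold higher number from compound 1 to compound 4 (0.10 log units; within the scatter).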

Compound 4, half-maximal inhibitory concentration: 107 nM
Beside the measured number, compound 4's estimate is 1.1-fold (0.03 log units) below it, and the stated range covers the measured number.
By their numbers in this assay, from the lowest: compounds 1, 2 and 4 (each within the scatter of the next); then compound 3.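

In this assay, the change to phenyl gives a 1.4-fold higher number from compound 1 to compound 4 (0.13 log units; within the scatter), and the exchange of pyridin-3-yl for phenyl gives a 1.3-fold higher number from compound 2 to compound 4 (0.10 log units; within the scatter). A six-membered aromatic ring of carbon only therefore stands level with both rings that carry a hetero atom, so on this aromatic carbon, the oxygen of furan-2-yl is not needed to keep the number in this range. No measurement at hand offers a reason for this. The compounds shown leave open how an amine, a carboxylic acid or a longer chain on this carbon would read. They also leave open how a phenyl bearing a single fluorine or methoxy group would compare.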